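A few compounds are considered here, and "the series" means these few. Any claim that something is new, unique, unknown or untested is made for them only; others in the source may bear on it.

Working notes on the series. Compound 1 (`CC[C@@H](C(=O)NO)N1CCCC1=O`) gives 1000 umol/kg in a functional assay on the whole organism with Mus musculus as the target (on this read-out higher numbers stand for an effect only at larger amounts of compound and lower numbers for an effect already at smaller amounts), as the first reference point. Compound 2 (`CC[C@@H](C(=O)NOC)N1CCCC1=O`) gives 1000 umol/kg in this assay and so stands level with compound 1 on the numbers at hand.

Within the data shown here, the next entry is compound 3 (`CC[C@@H](C(=O)NN)N1CCCC1=O`), which has no measurement yet. It carries amino in place of methoxy on an amide-type nitrogen, counted as amino in place of methoxy on an amide-type nitrogen in full.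

Among the measured compounds shown here, only one measured step bears on this change, and only indirectly. That step is no change at the digits printed from compound 1 to compound 2 (within the scatter) for methyl in place of hydrogen on an oxygen, and it stays within the scatter. For the measured compounds named here, no measured step swaps methoxy for amino, and two compounds give no trend in either direction. No shift beyond the scatter is therefore expected in this assay and no direction is favoured.

The expected move is no change at the digits printed from compound 2 to compound 3 (within the scatter) as an estimate and not a finding. For compound 3 the estimated value is 1000 umol/kg with an expected range from 400 umol/kg to 2500 umol/kg in this series.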

Compound 3, dose for half-maximal effect: 1000 umol/kg
Beside the measured number, compound 3's estimate shows no gap at the digits printed, and the stated range covers the measured number.
By their numbers in this assay, from the lowest: compounds 1, 2 and 3 (each within the scatter of the next).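

In this assay the swap of methoxy for amino on an amide-type nitrogen gives no change at the digits printed from compound 2 to compound 3 (within the scatter) and the swap of hydroxy for amino gives no change at the digits printed from compound 1 to compound 3 (within the scatter) on the same read-out. The earlier step touched only the group on the oxygen, whereas these two change the atom bound to the amide-type nitrogen itself, from oxygen to nitrogen, and the exchange of methoxy for amino also moves the count from 0 hydrogen-bond donors to 1 hydrogen-bond donor, all without a step beyond the scatter. No supporting data on hand bear on why the three compounds read alike.

Open is whether any group on this amide-type nitrogen separates from the three shown, for instance a dimethylamino group, a benzyloxy group or a longer chain such as butyl. Also open, going by these compounds, is whether a carboxylic acid in place of the whole substituted amide would stay level with compound 1 on the shared core, and whether changes elsewhere on that core would shift the read-out at all.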